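Methyl added to a phenyl ring: cytotoxicity expected unchanged

The compounds below may be only part of what the source reports. "The series", "measured", "known", "first", "only" and "open" are said of these compounds alone.

Compound 1 `Cc1nc(-c2cccnc2)sc1-c1nnc(-c2ccccc2Cl)o1`: > 100 ug/mL
Compound 2 `Cc1nc(-c2cccnc2)sc1-c1nnc(-c2ccc([N+](=O)[O-])cc2)o1`: > 100 ug/mL
Compound 3 `Cc1nc(-c2cccnc2)sc1-c1nnc(-c2ccccc2)o1`: > 100 ug/mL

In an ADME assay on HCT-116 cells (Homo sapiens) for cytotoxicity, read by MTT assay (a higher number here means that more compound is tolerated, a lower number that less compound is tolerated), compound 3 gives only a limit, not a number. Compound 1 likewise sits at a limit. Compound 2 also sits at a limit. The change to compound 4 `Cc1cccc(-c2nnc(-c3sc(-c4cccnc4)nc3C)o2)c1` is methyl in place of hydrogen on an aromatic carbon. Among the measured compounds shown here, two steps bear on it: a step that the two limits leave unreadable from compound 1 to compound 3 and a step that the two limits leave unreadable from compound 2 to compound 3. Both steps rest on the limit of > 100 ug/mL in this assay, at which 3 of the 3 values shown sit, and cannot be sized, so all that can be said is that no change in this ring so far moved a compound off the limit. The step expected is a step that the limit leaves unreadable from compound 3 to compound 4, nothing beyond the usual scatter. Compound 4 is therefore estimated at 150 ug/mL, within 70 ug/mL to 400 ug/mL, most likely again reported as a limit.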

Compound 4, half-maximal cytotoxic concentration: > 100 ug/mL
Compound 4: no number, only a limit; the forecaster's own chance of this, stated with the estimate: 85%; the middle value does not contradict the limit.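

No step from compound 3 or compound 1 to compound 4 can be read, because these compounds all sit at one limit: the limit of > 100 ug/mL in this assay, at which 4 of the 4 values shown sit.

Going by these compounds, what stays open is how much of each compound is actually tolerated in this assay, and whether any of these ring changes alters it.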